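Aryl exchange on an aromatic nitrogen in an endothelial growth assay

This account rests on a few compounds, and the source may have more. Where it says the series, first, only, none or still open, it means among the compounds named here.

Measured compounds, each read in an ADME assay on HUVEC cells (Homo sapiens) for antiproliferative activity, read by MTT assay, with a stated time of 48 h; a higher number here means a weaker inhibitor, a lower number a stronger inhibitor:
- compound 1 `Cc1ccc(Cl)cc1-n1nncc1CN1C(=O)C2(C(C#N)=C(N)Oc3c2c2nc4ccccc4nc2c2ccccc32)c2ccccc21` gives > 50000 nM, which is a limit of the assay.
- compound 2 `N#CC1=C(N)Oc2c(c3nc4ccccc4nc3c3ccccc23)C12C(=O)N(Cc1cnnn1-c1ccc(F)c(Cl)c1)c1ccccc12` gives > 50000 nM, which is a limit of the assay.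
- compound 3 `Cc1ccc(Cl)cc1-n1nncc1CN1C(=O)C2(C(C#N)=C(N)Oc3c(N)cc4nc5ccccc5nc4c32)c2ccccc21` gives > 50000 nM, which is a limit of the assay.

All three values sit at the limit of > 50000 nM in this assay, at which 3 of the 3 values shown sit, so no order among compound 1, compound 2 and compound 3 can be read in this assay, and none of them is called stronger or weaker than another.

Compound 1 and compound 2 share one core and differ in a single place: 3-chloro-4-fluorophenyl in place of 5-chloro-2-methylphenyl on an aromatic nitrogen. Going by these compounds, the step that the two limits leave unreadable from compound 1 to compound 2 is left unreadable by the two limits, so its size is unknown in either direction.

Compound 3 carries a different core; how the core of compound 3 differs from the core of compound 1 is not broken down here.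

Compound 4 `N#CC1=C(N)Oc2c(N)cc3nc4ccccc4nc3c2C12C(=O)N(Cc1cnnn1-c1ccc(F)c(Cl)c1)c1ccccc12` has not yet been measured in this assay. It stands to compound 3 as compound 2 stands to compound 1: 3-chloro-4-fluorophenyl in place of 5-chloro-2-methylphenyl on an aromatic nitrogen. The place of the change is described word for word as in the earlier pair, so this is the same change made on the second core.

Compound 4 is expected to stay at the assay limit, with an estimate of 50000 nM between 20000 nM and 120000 nM, because compound 3 sits at the limit of > 50000 nM in this assay, at which 3 of the 3 values shown sit, and the same change gave a step that the two limits leave unreadable from compound 1 to compound 2 without a readable shift. The step from compound 3 is accordingly expected to be a number no higher from compound 3 to compound 4 (the limit leaves the size open).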

Compound 4, half-maximal inhibitory concentration: > 50000 nM
Compound 4 was reported as a limit; the forecaster's own chance of this, stated with the estimate: 85%; the middle value sits exactly at the limit.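

In this assay compound 4 gives > 50000 nM as a limit of the assay. Among these compounds, the step from compound 3 to compound 4, like that from compound 1 to compound 2, cannot be read, so no new step follows: the limit of > 50000 nM in this assay, at which 4 of the 4 values shown sit.

The compounds shown leave open whether 3-chloro-4-fluorophenyl in place of 5-chloro-2-methylphenyl shifts the read-out on either core, and how the four compounds order among themselves.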